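From propyl to 2-chlorophenyl on the shared core

This account rests on a few compounds, and the source may have more. Where it says the series, first, only, none or still open, it means among the compounds named here.

For the measured compounds named here, in a functional assay on MCF7 cells (Homo sapiens) for antiproliferative activity, read by MTT assay, with a stated time of 72 h (on this read-out higher numbers stand for weaker inhibition and lower numbers for stronger inhibition), compound 1 `O=C(Nc1ccc(Nc2nccc(NC3CCCCC3)n2)cc1)Nc1ccc(Cl)c(C(F)(F)F)c1` gives 10800 nM and compound 2 `CCCNc1ccnc(Nc2ccc(NC(=O)Nc3ccc(Cl)c(C(F)(F)F)c3)cc2)n1` gives 4610 nM as the lower of the two numbers so far. Compound 3 `O=C(Nc1ccc(Nc2nccc(Nc3ccccc3Cl)n2)cc1)Nc1ccc(Cl)c(C(F)(F)F)c1` has 2-chlorophenyl in place of propyl on a nitrogen on an aromatic ring and is not yet measured. Going by the values given here, the only measured step at that nitrogen is a 2.3-fold lower number from compound 1 to compound 2 (0.37 log units; beyond the scatter) on swapping cyclohexyl for propyl. It is modest and brings in no aromatic group, so it gives no firm direction. In this assay no step beyond the scatter is therefore expected, and the estimated move is a 1.3-fold lower number from compound 2 to compound 3 (0.12 log units; within the scatter) on these numbers. For compound 3 a value of 3500 nM is estimated, with a likely range from 1000 nM to 12000 nM around it.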

Compound 3, half-maximal inhibitory concentration: 27900 nM
Compound 3: middle estimate off by 8.0-fold (0.90 log units), on the low side, and the stated range ends below it.
By their numbers in this assay, from the lowest: compound 2; then compound 1; then compound 3.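

At this nitrogen, the first aromatic group shown in this assay moves the number upward, giving a 6.1-fold higher number from compound 2 to compound 3 (0.78 log units; beyond the scatter) and also a 2.6-fold higher number from compound 1 to compound 3 (0.41 log units; beyond the scatter). So 2-chlorophenyl ranks behind both propyl and cyclohexyl here, and the position does respond to the group placed on it. No measurement available here accounts for this rise.

The compounds shown leave open whether the ring itself or its chlorine goes with the higher number. Plain phenyl would help separate the two, and a longer chain such as butyl would test the other direction.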